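Three Limit Values and a Fourth Analogue Expected to Match

The compounds below may be only part of what the source reports. "The series", "measured", "known", "first", "only" and "open" are said of these compounds alone.

compound 1 `CCc1nnc(SCC(=O)c2ccc(Cl)cc2)n1N1C(=O)c2ccccc2C1=O`: > 200000 nM
compound 2 `C=CCSc1nnc(-c2cc(OC)c(OC)c(OC)c2)n1N1C(=O)c2ccccc2C1=O`: > 200000 nM
compound 3 `COc1cc(-c2nnc(SCc3ccccc3Cl)n2N2C(=O)c3ccccc3C2=O)cc(OC)c1OC`: > 200000 nM

In a functional assay on A549 cells (Homo sapiens) for cytotoxicity, read by MTT assay, with a stated time of 48 h (on this read-out lower numbers stand for stronger inhibition and higher numbers for weaker inhibition), compound 1 gives > 200000 nM, which is a limit of the assay and not a number. Compound 2 gives > 200000 nM, again a limit. Compound 3 gives > 200000 nM, also a limit. The step that the two limits leave unreadable from compound 2 to compound 3 is therefore not readable. Compound 3 thus stands at the limit of > 200000 nM in this assay, at which 3 of the 3 values shown sit, with no value that separates it from the other two.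

Compound 4 `COc1cc(-c2nnc(SCC(=O)c3ccc(Cl)cc3)n2N2C(=O)c3ccccc3C2=O)cc(OC)c1OC` differs from compound 3 by (4-chlorophenyl)carbonyl in place of 2-chlorophenyl on a saturated chain carbon bound to a sulfur. For the measured compounds named here, compound 1 already carries this (4-chlorophenyl)carbonyl group on the same chain carbon and sits at the same limit, so no measured step gives a direction. Compound 4 is expected to remain at the limit, a step that the limit leaves unreadable from compound 3 to compound 4 being nothing beyond the scatter. The estimate for compound 4 is 300000 nM, between 100000 nM and 1000000 nM.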

Compound 4, half-maximal inhibitory concentration: 9030 nM
The estimate for compound 4 lay 33-fold (1.52 log units) above the measured number; measured number outside the range, below it.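

In this assay, for the compounds shown here, (4-chlorophenyl)carbonyl on a saturated chain carbon bound to a sulfur is the first change here with a readable effect, giving an at least 22-fold lower number from compound 3 to compound 4 (1.34 log units; beyond the scatter) in place of 2-chlorophenyl and an at least 22-fold lower number from compound 2 to compound 4 (1.34 log units; beyond the scatter) in place of vinyl. The same group alone is not enough, as 3,4,5-trimethoxyphenyl in place of ethyl on an aromatic carbon gives an at least 22-fold lower number from compound 1 to compound 4 (1.34 log units; beyond the scatter). Only compound 4 carries both groups and leaves the limit, which is not a number: the limit of > 200000 nM in this assay, at which 3 of the 4 values shown sit.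

The steps among the compounds at the limit cannot be read. The step to compound 4 adds the carbonyl and changes the chlorophenyl together, leaving open which one matters and whether a plain phenyl or an amine would serve there.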